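Removing the hydroxy group from compound 3

The compounds below may be only part of what the source reports. "The series", "measured", "known", "first", "only" and "open" are said of these compounds alone.

Measured in a functional assay on A549 cells (Homo sapiens) for inhibition, read by CCK-8 assay, with a stated time of 72 h, tested at 10 uM; a lower number here means less inhibition of growth, a higher number more inhibition of growth at the concentration tested:
- compound 1 `Cc1cccc(NC(=O)C2(C(=O)Nc3ccc(Nc4ncc5cc(C(=O)N(C)C)n(C6CCCC6)c5n4)cc3)CC2)c1`: 86.1%
- compound 2 `COc1ccc(NC(=O)C2(C(=O)Nc3ccc(Nc4ncc5cc(C(=O)N(C)C)n(C6CCCC6)c5n4)cc3)CC2)cc1`: 78.5%
- compound 3 `CN(C)C(=O)c1cc2cnc(Nc3ccc(NC(=O)C4(C(=O)Nc5ccc(O)cc5)CC4)cc3)nc2n1C1CCCC1`: 94.4%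

Compound 3 clearly exceeds only compound 2, with a number 15.9 percentage points higher from compound 2 to compound 3 (beyond the scatter). Against the other neighbour the data show a number 8.3 percentage points higher from compound 1 to compound 3 (within the scatter).

Compound 4 `CN(C)C(=O)c1cc2cnc(Nc3ccc(NC(=O)C4(C(=O)Nc5ccccc5)CC4)cc3)nc2n1C1CCCC1` differs from compound 3 by one change: hydrogen in place of hydroxy on an aromatic carbon. Among the measured compounds shown here, no measured step makes exactly this change. The closest guides are a number 15.9 percentage points higher from compound 2 to compound 3 (beyond the scatter) and a number 8.3 percentage points higher from compound 1 to compound 3 (within the scatter), which both compare the hydroxy compound with one lacking a free hydroxy. The expected result is a number 8.4 percentage points lower from compound 3 to compound 4 (within the scatter), so no step beyond the scatter is expected. The estimate for compound 4 is 86%, with an expected range of 75% to 95%.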

Compound 4, percent growth inhibition at one concentration: 88.8%
For compound 4 the middle estimate is 2.8 percentage points below the measured one; the range from low to high includes it.
By their numbers in this assay, from the lowest: compounds 2, 1, 4 and 3 (each within the scatter of the next, the first and the last beyond it).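

Removing the hydroxy group leaves a plain phenyl, and in this assay the free hydroxy on this ring is not required for growth inhibition (a number 5.6 percentage points lower from compound 3 to compound 4 (within the scatter)). Among the compounds shown here, the phenyl compound also sets a reference for the other rings: losing the methyl gives (a number 2.7 percentage points higher from compound 1 to compound 4 (within the scatter)), while losing the methoxy gives (a number 10.3 percentage points higher from compound 2 to compound 4 (beyond the scatter)), the only one of these three steps beyond the scatter. Nothing available explains these steps. Still open, going by these compounds, is how an amine or a carboxylic acid at this place on the ring would compare with hydroxy and hydrogen.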